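Fluoro to cyano on the sulfonyl aryl ring

This account rests on a few compounds, and the source may have more. Where it says the series, first, only, none or still open, it means among the compounds named here.

Compound 3 `CN1CCN(c2ccc(C3=NN(S(=O)(=O)c4ccc(F)cc4)C(c4ccc(N(C)C)cc4)C3)cc2)CC1` gives 15.7% in a functional assay on MDA-MB-231 cells (Homo sapiens) for inhibition, read by sulforhodamine B assay, tested at 10 uM (a higher number here means more inhibition at the concentration tested (going by the name of the read-out), a lower number less inhibition), and stands second highest of the three numbers measured. Compound 1 `CN1CCN(c2ccc(C3=NN(C(=O)/C=C/c4ccccc4)C(c4ccc(N(C)C)cc4)C3)cc2)CC1` gives 35.9% in this assay, and compound 2 `CN1CCN(c2ccc(C3=NN(S(=O)(=O)C4CC4)C(c4ccc(N(C)C)cc4)C3)cc2)CC1` gives 3.7%. For the measured compounds named here, the steps into compound 3 are a number 20.2 percentage points lower from compound 1 to compound 3 (beyond the scatter) and a number 12 percentage points higher from compound 2 to compound 3 (beyond the scatter), both beyond the scatter; the second is the only measured step that varies the group on the sulfonyl sulfur alone.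

Compound 4 `CN1CCN(c2ccc(C3=NN(S(=O)(=O)c4ccc(C#N)cc4)C(c4ccc(N(C)C)cc4)C3)cc2)CC1` differs from compound 3 by cyano in place of fluoro on an aromatic carbon, placed on the sulfonyl aryl ring para to a large group. Going by the values given here, no measured step alters a substituent on that ring, so the measured series gives no direct guide to the size of this change; the nearest comparison, the modest gain from cyclopropyl to 4-fluorophenyl, concerns a larger swap. The step is therefore expected to stay within the scatter, estimated as a number 2.3 percentage points higher from compound 3 to compound 4 (within the scatter). Compound 4 is thus estimated at 18%, with a range of 5% to 35%.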

Compound 4, a percentage reported as inhibition, at one concentration (the size of the read-out at that concentration, not a potency): 99.8%
For compound 4 the middle estimate is 81.8 percentage points below the measured one; measured number above the stated range.
By their numbers in this assay, from the lowest: compound 2; then compound 3; then compound 1; then compound 4.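

In this assay the substituent on the sulfonyl aryl ring proves a strong determinant of the read-out: a number 84.1 percentage points higher from compound 3 to compound 4 (beyond the scatter) is the outcome of cyano in place of fluoro, a swap of one small group at a single aromatic carbon. For the compounds shown here, the identity of the group on the sulfonyl sulfur also spans far more than the earlier compounds showed, with a number 96.1 percentage points higher from compound 2 to compound 4 (beyond the scatter) for 4-cyanophenyl in place of cyclopropyl, and (4-cyanophenyl)sulfonyl now exceeds (2-phenylethenyl)carbonyl on the amine nitrogen in the ring, with a number 63.9 percentage points higher from compound 1 to compound 4 (beyond the scatter) as the step. Nothing at hand accounts for the size of the cyano effect.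

On these data alone, whether the gain is specific to cyano or extends to groups such as nitro, chloro or a carboxylic acid at this place remains open. Potency also remains open, since these numbers come from a single concentration.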